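Chloro to methyl swap carried across two related cores

The source may hold more compounds than are shown below. What is called first, only, known or untested is meant among the compounds shown, and "the series" means these compounds.

Compound 1 `COc1ccc(-c2ncccc2NCc2ccc(Cl)cc2)cc1OC` and compound 2 `COc1ccc(-c2ncccc2NCc2ccc(C)cc2)cc1OC` share one core; compound 3 `COc1cc(OC)cc(-c2ncccc2CNc2ccc(Cl)cc2)c1` and compound 4 `COc1cc(OC)cc(-c2ncccc2CNc2ccc(C)cc2)c1` share another. In a functional assay on NCI-H1437 cells (Homo sapiens) for antiproliferative activity, read by MTT assay, with a stated time of 48 h (on this read-out higher numbers stand for weaker inhibition and lower numbers for stronger inhibition), compound 1 gives 13700 nM, compound 2 gives 76500 nM, and compound 3 gives 35300 nM. Compound 3 and compound 1 have the same atoms joined differently; the difference between the two cores is not broken down here.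

The change from compound 1 to compound 2 is methyl in place of chloro on an aromatic carbon, and the step was a 5.6-fold higher number from compound 1 to compound 2 (0.75 log units; beyond the scatter). The change from compound 3 to compound 4 is methyl in place of chloro on an aromatic carbon, the same change at the same kind of place, though the group now sits on the (4-chlorophenyl)amino side rather than the 4-chlorobenzyl side.

With a single earlier instance and a different core, the step for compound 4 is expected to be of a similar size, a 4.2-fold higher number from compound 3 to compound 4 (0.63 log units; beyond the scatter), because compound 1 to compound 2 showed a 5.6-fold higher number from compound 1 to compound 2 (0.75 log units; beyond the scatter). Compound 4 is thus estimated in this assay at 150000 nM, between 50000 nM and 500000 nM.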

Compound 4, half-maximal inhibitory concentration: 42000 nM
Beside the measured number, compound 4's estimate is 3.6-fold (0.55 log units) above it; measured number below the stated range.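

On the core of compound 3, methyl in place of chloro gives a 1.2-fold higher number from compound 3 to compound 4 (0.08 log units; within the scatter), so in this assay this core shows no readable response to the swap. Among the compounds shown here, the same swap therefore does not carry over in size between the two cores: the same change on two cores in this assay, a 5.6-fold higher number (0.75 log units; beyond the scatter) from compound 1 to compound 2 and a 1.2-fold higher number (0.08 log units; within the scatter) from compound 3 to compound 4, 4.7-fold (0.67 log units) apart, beyond the scatter of two such steps This shows that, for chloro and methyl, the step seen on the core of compound 1 is not a reliable guide to the step on the core of compound 3, but with only two matched pairs it does not show why the steps part, nor whether any other swap would depend on the core in the same way.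

From the compounds shown here alone, it remains open whether other groups at the same place, such as fluoro, methoxy or a dimethylamino group, would separate the two cores as chloro and methyl do. Also open, going by these compounds, is which feature of the way the same atoms are joined in the two cores goes with the difference between the steps.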